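A shorter chain at one point on the shared core

The source may report more compounds than this note shows. Statements on the series, on what has been measured and on what is new or still open speak of the compounds shown alone.

Compound 1 has the structure `CCCCCNc1nc(N)c2nc(O)n(Cc3ccccc3)c2n1`. Going by the values given here, in a functional assay (spleen, spleen) for activation, with Mus musculus as the target (a lower number here means that less compound is needed, a higher number that more compound is needed for the effect), compound 1 gives 0.1 uM, the highest of the two numbers measured so far. Its nearest neighbour is compound 2, with the structure `CCCCOc1nc(N)c2[nH]c(=O)n(Cc3ccccc3)c2n1`, which in this assay reaches 0.001 uM, a lower number, with a gap that lies well beyond the usual scatter. Compound 3, with the structure `Nc1ncnc2c1nc(O)n2C1CCCC1`, gives in this assay only > 10 uM, which is a limit of the assay rather than a number; this is the case noted as the limit of > 10 uM in this assay, at which 1 of the 3 values shown sits.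

The next compound, compound 4, has the structure `CSc1nc(N)c2nc(O)n(Cc3ccccc3)c2n1`. It differs from compound 1 in one place: methylsulfanyl in place of pentylamino on an aromatic carbon. A longer chain bearing a hydrogen-bond donor is thus replaced by a much smaller group without one, on the same aromatic carbon.

Among the compounds with values here, no measured pair shows exactly this kind of exchange, so the size of the step can only be guessed. The step from compound 1 to compound 4 is expected to be a 10-fold higher number from compound 1 to compound 4 (1.00 log units; beyond the scatter), that is, a rise in the number beyond the scatter. Compound 4 is therefore estimated at 1 uM, with a range from 0.1 uM to 10 uM.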

Compound 4, minimum effective concentration: 0.1 uM
The estimate for compound 4 lay 10-fold (1.00 log units) above the measured number, within the range that was stated.
By their numbers in this assay, from the lowest: compound 2; then compounds 1 and 4 (each within the scatter of the next). At a limit, above all of these: compound 3.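

In this assay the exchange gives no change at the digits printed from compound 1 to compound 4 (within the scatter) and so shows that, on this aromatic carbon, pentylamino can give way to methylsulfanyl without a difference that can be read. The entering group has far fewer heavy atoms and no hydrogen-bond donor, so in this one pair neither the long chain nor the donor of pentylamino is needed to keep the number where it stands. The earlier compounds shown here could not show this, as no two of them formed a pair with a step that could be read.

Because the exchange alters the chain length and the linking atom together, the compounds shown leave open what each does alone, and a methylamino group or a pentylsulfanyl chain on this same carbon would pull the two apart. Nothing in the data shown speaks to why the number holds across this exchange.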